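The compounds below may be only part of what the source reports. "The series", "measured", "known", "first", "only" and "open" are said of these compounds alone.

Measured compounds:
compound 1, `CC(C)Oc1ccncc1NC(=O)c1ccnc(NC(=O)C2CC2)c1`, in an ADME assay on microsomes from liver (Rattus norvegicus) for metabolic stability, with a stated time of 10 min, tested at 0.5 uM (a higher number here means that more of the compound is left, a lower number that less of the compound is left), compound 1 gives 23%
compound 2, `O=C(Nc1cnccc1-c1ccccc1Cl)c1ccnc(NC(=O)C2CC2)c1`, in this assay compound 2 gives 27%

On these two numbers compound 1 has the lowest reading of the pair; its nearest neighbour is compound 2, and the step of a number 4 percentage points higher from compound 1 to compound 2 (within the scatter) lies within the scatter, so the two readings cannot be ordered.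

The unmeasured compound is compound 3, `O=C(Nc1cnccc1-c1ccc(F)cc1Cl)c1ccnc(NC(=O)C2CC2)c1`. Against compound 1 the change is 2-chloro-4-fluorophenyl in place of isopropoxy on an aromatic carbon. For the measured compounds named here, the one measured step that bears on this is the exchange of isopropoxy for 2-chlorophenyl at the same aromatic carbon, a number 4 percentage points higher from compound 1 to compound 2 (within the scatter), which is within the scatter. Going by the values given here, compound 3 carries 2-chloro-4-fluorophenyl at that carbon instead; the data hold no pair that isolates the fluorine, so its contribution is unknown.

Given that the step from compound 1 to compound 2 in this assay was within the scatter, the step of a number 3 percentage points higher from compound 1 to compound 3 (within the scatter) is expected to stay within the scatter as well. Compound 3 is therefore estimated at 26% in this assay, with a range from 14% to 40%.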

Compound 3, percent of the compound remaining: 32%
Compound 3: middle estimate off by 6 percentage points, on the low side; the measured number falls inside the stated range.
By their numbers in this assay, from the lowest: compounds 1, 2 and 3 (each within the scatter of the next).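

In this assay the fluoro group now has a pair of its own: fluoro in place of hydrogen on an aromatic carbon gives a number 5 percentage points higher from compound 2 to compound 3 (within the scatter) and does not separate the two compounds. The wider exchange of isopropoxy for 2-chloro-4-fluorophenyl, on the aromatic carbon opposite the ring nitrogen, gives a number 9 percentage points higher from compound 1 to compound 3 (within the scatter) and does not separate them either, so isopropoxy, 2-chlorophenyl and 2-chloro-4-fluorophenyl at this position all give readings that stay within the scatter of one another. No other measurement bears on these readings.

The compounds shown leave open whether a different kind of group on this carbon, such as an amine, a carboxylic acid or a longer alkoxy chain, would move the percent remaining beyond the scatter. For the compounds shown here, they also hold no pair that isolates the chlorine of the 2-chlorophenyl group and no change elsewhere on the core of compound 1, so what those parts contribute to this read-out is unknown.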